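Small alkyl swap on the sulfur chain

The source may report more compounds than this note shows. Statements on the series, on what has been measured and on what is new or still open speak of the compounds shown alone.

Compound 1 `Cc1cc(Nc2cc(-c3ccccc3)[nH]n2)n2nc(SCc3ccc([N+](=O)[O-])cc3)nc2n1` gives 5060 nM
Compound 2 `CCCSc1nc2nc(C)cc(Nc3cc(-c4ccccc4)[nH]n3)n2n1` gives > 50000 nM (a limit)
Compound 3 `Cc1cc(Nc2cc(-c3ccccc3)[nH]n2)n2nc(SCC3CC3)nc2n1` is not yet measured

In a functional assay on MCF7 cells (Homo sapiens) for inhibition, read by MTT assay, with a stated time of 72 h (a higher number here means a weaker inhibitor, a lower number a stronger inhibitor), compound 2 stands at > 50000 nM and this is a limit, not a number. Compound 3 carries cyclopropyl in place of ethyl on a saturated chain carbon bound to a sulfur. Among the compounds with values here, the one measured step that bears on this is an at least 9.8-fold higher number from compound 1 to compound 2 (0.99 log units; beyond the scatter) (ethyl in place of 4-nitrophenyl), and it ends at the limit of > 50000 nM in this assay, at which 1 of the 2 values shown sits (so its full size is unknown). Compound 3 also lacks that 4-nitrophenyl, so it is expected to stay close to compound 2. The expected change is an at least 1.2-fold lower number from compound 2 to compound 3 (0.09 log units; that floor lies within the scatter) (none beyond the scatter). The estimate for compound 3 is 40000 nM (range 12000 nM to 90000 nM).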

Compound 3, half-maximal inhibitory concentration: > 50000 nM
Compound 3 ended at the assay's limit; the forecaster's own chance of this, stated with the estimate: 55%; at least 1.2-fold (0.09 log units) between middle value and limit.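

In this assay, exchanging the 4-nitrophenyl for cyclopropyl gives an at least 9.8-fold higher number from compound 1 to compound 3 (0.99 log units; beyond the scatter), so a small alkyl group carrying a ring fares no better here than ethyl in reaching the value of compound 1. Compound 3 gives > 50000 nM, which is a limit. The step between compound 2 and compound 3 cannot be read, and the two now share one ceiling: the limit of > 50000 nM in this assay, at which 2 of the 3 values shown sit.

Open, from the compounds shown here alone, is whether the activity of compound 1 needs the nitro group or only the aromatic ring, which a plain phenyl or a 4-aminophenyl at this place would separate.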